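The source may report more compounds than this note shows. Statements on the series, on what has been measured and on what is new or still open speak of the compounds shown alone.

Measured so far in an ADME assay on microsomes (Rattus norvegicus) for metabolic stability (on this read-out higher numbers stand for a longer-lived compound and lower numbers for a shorter-lived compound), are two compounds, given here with their values
compound 1 (`CC(C)C(=O)N1N=CCC1c1ccccc1`) gives (1.33 h)
compound 2 (`N#Cc1cc(N2CCC(C(=O)N3N=CC[C@H]3c3cc(F)cc(F)c3)CC2)ncn1`) gives (1.15 h)

These two values lie within the usual scatter of each other, so compound 1 stands level with compound 2 and neither can be ranked on these numbers. The next compound to be tested is compound 3 (`O=C(C1CCOCC1)N1N=CCC1c1ccccc1`), which keeps the core of compound 1 and carries oxan-4-yl in place of isopropyl on a carbonyl carbon. Going by the values given here, no pair of measured compounds differs in one place, so the data hold no direct precedent for this change. Compound 2 differs from compound 1 in more than one place, yet compound 2 still gives (1.15 h), and on that slim basis no step beyond the scatter is expected in this assay for compound 3. The estimated change is small (a 1.1-fold higher number from compound 1 to compound 3 (0.02 log units; within the scatter)). For compound 3 the expected value is (1.4 h), with an estimated range from 0.7 h to (2.8 h).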

Compound 3, half-life: > 1.5 h
Compound 3 was reported as a limit (the forecaster's own chance of this, stated with the estimate: 10%); middle value at least 1.0-fold (0.02 log units) from the limit.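

Compound 3 is reported in this assay as > 1.5 h, which is a limit of the assay and not a number. Going by these compounds alone, the one-place step reads an at least 1.1-fold higher number from compound 1 to compound 3 (0.05 log units; that floor lies within the scatter), the first direct reading at this position, and it shows that a carbonyl carbon whose other neighbour is the amide-type nitrogen in a ring can carry oxan-4-yl in place of isopropyl without a loss of half-life beyond the scatter, even though the entering group brings more heavy atoms, a six-membered non-aromatic ring and a hydrogen-bond acceptor. The true size of this step cannot be told, and whether it reaches beyond the scatter stays unsettled, because the reading of compound 3 ends at a ceiling: the limit of > 1.5 h in this assay, at which 1 of the 3 values shown sits.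

The compounds shown leave open how far compound 3 lies past its limit, and whether the ring or its oxygen matters more at this place, a question that cyclohexyl, the all-carbon ring of the same size, would speak to. They also leave open how this position would read with an amine or a carboxylic acid on the ring.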